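The source may hold more compounds than are shown below. What is called first, only, known or untested is meant among the compounds shown, and "the series" means these compounds.

Three compounds have been measured so far in a functional assay on DU-145 cells (Homo sapiens) for inhibition, read by trypan blue exclusion, with a stated time of 72 h; on this read-out higher numbers stand for weaker inhibition and lower numbers for stronger inhibition:

compound 1 `COC(=O)Cn1c(=O)c(S(=O)(=O)c2ccc(F)cc2F)cc2cnc(Nc3ccc4[nH]ccc4c3)nc21`: 10000 nM
compound 2 `O=c1c(S(=O)(=O)c2ccc(F)cc2F)cc2cnc(Nc3ccc4[nH]ccc4c3)nc2n1C1CCCC1`: 5000 nM
compound 3 `Cn1c(=O)c(S(=O)(=O)c2ccc(F)cc2F)cc2cnc(Nc3ccc4occc4c3)nc21`: 15000 nM

Compound 2 stands at 5000 nM. Compound 1 lies within the usual scatter of it, so those two cannot be told apart. Compound 3 reads a higher number, and that gap goes beyond the scatter.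

The next compound, compound 4 `CCn1c(=O)c(S(=O)(=O)c2ccc(F)cc2F)cc2cnc(Nc3ccc4[nH]ccc4c3)nc21`, keeps everything in compound 2 except one group on an aromatic nitrogen: ethyl in place of cyclopentyl on an aromatic nitrogen. In words, ethyl comes in place of cyclopentyl. Among the compounds with values here, only one measured step bears on this spot: a 2.0-fold lower number from compound 1 to compound 2 (0.30 log units; within the scatter), where cyclopentyl took the place of (methoxycarbonyl)methyl on that same nitrogen. Even that exchange did not move the number beyond the scatter. Compound 3 differs from the others in more than one place, so no clean step can be read from it. Within the data shown here, one step is thin evidence, and no compound measured so far carries ethyl.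

A change beyond the scatter in this assay is therefore not expected, and any small drift is expected to be upward. The estimated shift is a 1.6-fold higher number from compound 2 to compound 4 (0.20 log units; within the scatter). Compound 4 is expected at 8000 nM, with an estimated range of 3000 nM to 20000 nM.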

Compound 4, half-maximal inhibitory concentration: 750 nM
Compound 4: the middle estimate sits 11-fold (1.03 log units) above what was measured, and the stated range ends above it.
By their numbers in this assay, from the lowest: compound 4; then compounds 2, 1 and 3 (each within the scatter of the next, the first and the last beyond it).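

In this assay, within the data shown here, this nitrogen turns out to be far more sensitive than the earlier compounds suggested: the one earlier step here stayed within the scatter, whereas ethyl in place of cyclopentyl gives a 6.7-fold lower number from compound 2 to compound 4 (0.82 log units; beyond the scatter) and lies clearly beyond it. Compared with compound 1, methyl in place of methoxycarbonyl at the end of the chain on the same nitrogen gives a 13-fold lower number from compound 1 to compound 4 (1.12 log units; beyond the scatter) as a still larger step, so two different exchanges at this one spot both lead to compound 4 and both move the number beyond the scatter, which means the group on this nitrogen can strongly change the read-out while the rest of the molecule stays the same. Why ethyl stands out from cyclopentyl and from the ester-bearing chain cannot be said, as nothing measured on these compounds speaks to a cause.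

The compounds shown leave open whether a longer chain such as propyl would keep this stronger inhibition or lose it. They also leave open how an ethyl chain ending in an amine or a carboxylic acid would read at this nitrogen.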